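From Compound 3 to Compound 4: A Carbamoyl Exchange

This account rests on a few compounds, and the source may have more. Where it says the series, first, only, none or still open, it means among the compounds named here.

In a functional assay on RKOp27 cells (Homo sapiens) for cytotoxicity, read by MTT assay, with a stated time of 3 days (on this read-out higher numbers stand for weaker inhibition and lower numbers for stronger inhibition), compound 1 `CCNc1nc(SCc2nc3ccccc3[nH]2)nc(-c2ccccc2)c1C#N` gives 7.35 nM while compound 2 `N#Cc1c(Nc2nccs2)nc(SCc2nc3ccccc3[nH]2)nc1-c1ccccc1` gives 3.2 nM and compound 3 `N#Cc1c(NNC(N)=S)nc(SCc2nc3ccccc3[nH]2)nc1-c1ccccc1` gives 3.2 nM on the same scale. Compound 3 thus stands level with compound 2, and the pair holds the lowest number of the three.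

Compound 4 `N#Cc1c(NC(N)=O)nc(SCc2nc3ccccc3[nH]2)nc1-c1ccccc1` differs from compound 3 in one place, on a nitrogen on an aromatic ring whose other neighbours are aromatic carbon, where carbamoyl enters and a group of 3 heavy atoms (1 carbon, 1 nitrogen, 1 oxygen; no ring) in place of a group of 4 heavy atoms (1 carbon, 2 nitrogen, 1 sulfur; no ring), on a nitrogen on an aromatic ring is the whole change. For the measured compounds named here, no measured compound carries carbamoyl, so the evidence is indirect. Exchanges on this nitrogen have moved the number only a little. The step of a 2.3-fold lower number from compound 1 to compound 2 (0.36 log units; beyond the scatter) brought in 1,3-thiazol-2-yl, and the step of a 2.3-fold lower number from compound 1 to compound 3 (0.36 log units; beyond the scatter) brought in the open group of 4 heavy atoms. Both are modest, and the step of no change at the digits printed from compound 2 to compound 3 (within the scatter) lies within the scatter.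

Given those sizes, only a small move towards a higher number is expected in this assay for this exchange. The estimated 1.4-fold higher number from compound 3 to compound 4 (0.15 log units; within the scatter) is expected to stay within the scatter. For compound 4 the expected value is 4.5 nM with 2 nM to 12 nM as the estimated range.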

Compound 4, half-maximal inhibitory concentration: 2.5 nM
Estimate against measurement, compound 4: 1.8-fold (0.26 log units) above, within the range that was stated.
By their numbers in this assay, from the lowest: compounds 4, 2 and 3 (each within the scatter of the next); then compound 1.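

In this assay the step of a 1.3-fold lower number from compound 3 to compound 4 (0.11 log units; within the scatter) and the step of a 1.3-fold lower number from compound 2 to compound 4 (0.11 log units; within the scatter) both lie within the scatter, so carbamoyl stands level with the open group of 4 heavy atoms and with 1,3-thiazol-2-yl on a nitrogen on an aromatic ring. Sulfur in the group on this nitrogen is therefore not needed to hold the number at this level: compound 2 and compound 3 both carry it, whereas compound 4 has a carbonyl oxygen in its place and no sulfur, and compound 1, with ethyl, also lacks sulfur but goes against any simple reading in which sulfur alone sets the number. For the compounds shown here, the step of a 2.9-fold lower number from compound 1 to compound 4 (0.47 log units; beyond the scatter) is beyond the scatter and the widest yet seen at this position, though it is still modest, and it leaves ethyl as the only group of the four set apart from the others.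

As far as these compounds go, whether a plain amine, a carboxylic acid or a longer chain on this nitrogen would stay level with carbamoyl remains open, as does how far the position tolerates change in other cell lines. Nothing in the data shown bears on what lies behind these small steps.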